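Urea series: isoquinolinone to quinolin-7-yl on the amide nitrogen

A few compounds are considered here, and "the series" means these few. Any claim that something is new, unique, unknown or untested is made for them only; others in the source may bear on it.

Measured:
compound 1 `CN(C)C1(Cc2ccccc2)CCN(c2cc(C(F)(F)F)ccc2CNC(=O)Nc2cccc3ccc(O)cc23)CC1` — 0.46 nM
compound 2 `CN(C)C1(Cc2ccccc2)CCN(c2cc(C(F)(F)F)ccc2CNC(=O)Nc2cccc3c(=O)[nH]ccc23)CC1` — 111 nM

Compound 2 stands at the higher of the two numbers in an assay on CHO cells for displacement of a labelled ligand from transient receptor potential cation channel subfamily V member 1 (Homo sapiens), read by scintillation counting, with a stated time of 60 min; on this read-out higher numbers stand for weaker inhibition and lower numbers for stronger inhibition; the step of a 240-fold higher number from compound 1 to compound 2 (2.38 log units; beyond the scatter) shows the gap to compound 1. Compound 3 `CN(C)C1(Cc2ccccc2)CCN(c2cc(C(F)(F)F)ccc2CNC(=O)Nc2ccc3cccnc3c2)CC1` is not yet measured. It differs from compound 2 in a group of 10 heavy atoms (9 carbon, 1 nitrogen; one six-membered aromatic ring of carbon only, one six-membered aromatic ring with 1 hetero atom) in place of a group of 11 heavy atoms (9 carbon, 1 nitrogen, 1 oxygen; one six-membered aromatic ring of carbon only, one six-membered aromatic ring with 1 hetero atom), on an amide-type nitrogen. No measured step covers this change; the only step shown swaps a different pair of groups at the same place, and its size is given above. The direction for compound 3 is therefore uncertain; a step of a 4.4-fold lower number from compound 2 to compound 3 (0.65 log units; beyond the scatter) towards compound 1 is expected, and compound 3 is estimated at 25 nM (range 3 nM to 200 nM).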

Compound 3, inhibition constant: 14.1 nM
Estimate against measurement, compound 3: 1.8-fold (0.25 log units) above; the measured number falls inside the stated range.
By their numbers in this assay, from the lowest: compound 1; then compound 3; then compound 2.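

In this assay, quinolin-7-yl on the amide-type nitrogen, with no carbonyl and no hydrogen-bond donor in the group, recovers part of the earlier loss (a 7.9-fold lower number from compound 2 to compound 3 (0.90 log units; beyond the scatter)). Among the compounds shown here, it still falls short of 7-hydroxynaphthalen-1-yl (a 31-fold higher number from compound 1 to compound 3 (1.49 log units; beyond the scatter)), so a hydrogen-bond donor in the group is not required for a number in this range, though the best number so far belongs to the group that carries one. No evidence on the cause of either step is available.

On these data alone, whether the remaining gap to compound 1 lies in the hydroxyl or in the ring nitrogen stays open. A quinolin-7-yl carrying a hydroxyl or an amine would test this.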